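The source may report more compounds than this note shows. Statements on the series, on what has been measured and on what is new or still open speak of the compounds shown alone.

Four compounds share a common right-hand part and differ in the five-membered aromatic ring on the left and in the small alkyl group carried on one of that ring's nitrogens. Compound 1 `CCCn1ncnc1-c1ccccc1NCC1=NCCN1` and compound 2 `CC(C)n1ncnc1-c1ccccc1NCC1=NCCN1` have the same core, and in an in vitro functional assay on cells (Fibroblast) for agonist activity at Alpha-1D adrenergic receptor (Homo sapiens) (a lower number here means that less compound is needed, a higher number that more compound is needed for the effect), compound 1 gives 251 nM. For compound 2 the same assay gives 3160 nM. Going by the values given here, the only change between them is isopropyl in place of propyl on an aromatic nitrogen, and it brings a 13-fold higher number from compound 1 to compound 2 (1.10 log units; beyond the scatter).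

Compound 3 `CCCn1nccc1-c1ccccc1NCC1=NCCN1` has a different core; how the core of compound 3 differs from the core of compound 1 is not broken down here. In this assay compound 3 sits at a limit of the assay rather than at a number, < 100000 nM, which is the limit of < 100000 nM in this assay, at which 1 of the 3 values shown sits.

Compound 4 `CC(C)n1nccc1-c1ccccc1NCC1=NCCN1` is obtained from compound 3 by isopropyl in place of propyl on an aromatic nitrogen. Among the compounds with values here, this is the same kind of change as the one from compound 1 to compound 2, not the same change: in compound 3 the aromatic nitrogen belongs to a five-membered aromatic ring with 2 nitrogen, whereas in compound 1 it belongs to a five-membered aromatic ring with 3 nitrogen and the position is two ring bonds from the ring nitrogen. Only one measured example of this kind of change exists among these compounds, so any expectation rests on a single step and on a starting point that is itself only a limit. The step from compound 3 to compound 4 is expected to be a step that the limit leaves unreadable from compound 3 to compound 4, on the grounds that the same kind of change gave a 13-fold higher number from compound 1 to compound 2 (1.10 log units; beyond the scatter). Compound 4 is therefore expected to be a weak compound in this assay, with an estimated value of 40000 nM, somewhere between 5000 nM and 100000 nM.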

Compound 4, half-maximal effective concentration: < 100000 nM
Compound 4: a limit, no number; the forecaster's own chance of this, stated with the estimate: 50%; the middle value is on the limit's open side.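

In this assay compound 4 gives < 100000 nM, a limit of the assay and not a number. Compound 3 stands at a limit as well, so no step can be read between compound 3 and compound 4: the limit of < 100000 nM in this assay, at which 2 of the 4 values shown sit. The compounds shown leave open whether isopropyl in place of propyl changes the number on the core of compound 3 as it does on the core of compound 1.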